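Notes on the series: from compound 1 to compound 4

This account rests on a few compounds, and the source may have more. Where it says the series, first, only, none or still open, it means among the compounds named here.

Going by the values given here, in a functional assay on HepG2 cells (Homo sapiens) for inhibition, read by MTT assay, with a stated time of 48 h (a higher number here means a weaker inhibitor, a lower number a stronger inhibitor), compound 1 (`CCOC(=O)C1=C(N/C=N/c2nnc(S(N)(=O)=O)s2)Nc2[nH]nc(C)c2C1c1ccc(N(C)C)cc1`) gives 38100 nM, the highest of the three numbers so far. Compound 2 (`CCOC(=O)C1=C(NN=C(C#N)C#N)Nc2[nH]nc(C)c2C1c1ccc(N(C)C)cc1`) gives 13700 nM, and compound 3 (`CCOC(=O)C1=C(N/C=N/c2ncc(-c3ccccc3)s2)Nc2[nH]nc(C)c2C1c1ccc(N(C)C)cc1`) gives 9790 nM. Compound 4 (`CCOC(=O)C1=C(N/N=C(/Br)c2ccccc2)Nc2[nH]nc(C)c2C1c1ccc(N(C)C)cc1`) has not yet been measured. Its change from compound 1 is a group of 9 heavy atoms (7 carbon, 1 nitrogen, 1 bromine; one six-membered aromatic ring of carbon only) in place of a group of 11 heavy atoms (3 carbon, 4 nitrogen, 2 oxygen, 2 sulfur; one five-membered aromatic ring with 3 hetero atoms), on an amine nitrogen. Among the compounds with values here, two measured steps bear on this change, since each removes the sulfamoyl-bearing ring of compound 1: a 2.8-fold lower number from compound 1 to compound 2 (0.44 log units; beyond the scatter) and a 3.9-fold lower number from compound 1 to compound 3 (0.59 log units; beyond the scatter). Neither introduces the new group, so the guidance is only approximate. A modest step to a lower number is therefore expected in this assay. The estimated step is a 3.2-fold lower number from compound 1 to compound 4 (0.50 log units; beyond the scatter). For compound 4 the expected value is 12000 nM, with an estimated range of 5000 nM to 30000 nM.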

Compound 4, half-maximal inhibitory concentration: 72000 nM
Compound 4: the middle estimate sits 6.0-fold (0.78 log units) below what was measured; measured number outside the range, above it.
By their numbers in this assay, from the lowest: compounds 3 and 2 (each within the scatter of the next); then compounds 1 and 4 (each within the scatter of the next).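

At this amine nitrogen, losing the sulfamoyl-bearing ring of compound 1 does not by itself bring a lower number in this assay: a 1.9-fold higher number from compound 1 to compound 4 (0.28 log units; within the scatter) lies within the scatter. The choice of replacement group matters, as a 5.3-fold higher number from compound 2 to compound 4 (0.72 log units; beyond the scatter) is beyond the scatter. Nothing measured here accounts for that gap.

Open, from the compounds shown here alone, is how the bromine and the carbon-only aromatic ring of compound 4 each contribute to this result. A chlorine in place of the bromine, or a carboxylic acid on that ring, would test this.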